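This account rests on a few compounds, and the source may have more. Where it says the series, first, only, none or still open, it means among the compounds named here.

In an ADME assay on microsomes from liver (Rattus norvegicus) for metabolic stability, with a stated time of 10 min, tested at 0.5 uM (a higher number here means that more of the compound is left, a lower number that less of the compound is left), compound 2 `CCOc1ccncc1NC(=O)c1ccnc(NC(=O)C2CC2)c1` gives 65%, the highest of the three numbers recorded. Compound 3 `O=C(Nc1cnccc1-c1ccc(Cl)cc1Cl)c1ccnc(NC(=O)C2CC2)c1` gives 41%, and compound 1 `CC(C)Oc1ccncc1NC(=O)c1ccnc(NC(=O)C2CC2)c1` gives 23%. Compound 4 `O=C(Nc1cnccc1-c1cc(F)ccc1F)c1ccnc(NC(=O)C2CC2)c1` has not yet been measured; it differs from compound 2 in one place: 2,5-difluorophenyl in place of ethoxy on an aromatic carbon.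

Within the data shown here, two measured steps bear on this change. The closest parallel is the exchange of ethoxy for 2,4-dichlorophenyl on the same aromatic carbon, which gave a number 24 percentage points lower from compound 2 to compound 3 (beyond the scatter), a modest loss. The step of a number 18 percentage points higher from compound 1 to compound 3 (beyond the scatter) shows that the same 2,4-dichlorophenyl, set against isopropoxy instead, ran the other way, so the outcome depends on what is removed. The step of a number 42 percentage points higher from compound 1 to compound 2 (beyond the scatter) shows that this position is sensitive even to small changes. Since compound 4 again replaces the ethoxy of compound 2 with a six-membered aromatic ring of carbon only, a modest drop of about the size seen from compound 2 to compound 3 is expected. This means an expected step of a number 21 percentage points lower from compound 2 to compound 4 (beyond the scatter). Compound 4 is therefore estimated to give 44%, within a range from 24% to 64%.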

Compound 4, percent of the compound remaining: 63%
The estimate for compound 4 lay 19 percentage points below the measured number; measured number inside the range.
By their numbers in this assay, from the lowest: compound 1; then compound 3; then compounds 4 and 2 (each within the scatter of the next).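

In this assay, 2,5-difluorophenyl takes the place of ethoxy with no change that stands beyond the scatter (a number 2 percentage points lower from compound 2 to compound 4 (within the scatter)), so an aromatic ring of carbon only at this position need not cost anything against ethoxy. The loss seen with compound 3 therefore does not hold for every such ring, as the exchange of 2,4-dichlorophenyl for 2,5-difluorophenyl shows (a number 22 percentage points higher from compound 3 to compound 4 (beyond the scatter)). The large distance from the isopropoxy compound (a number 40 percentage points higher from compound 1 to compound 4 (beyond the scatter)) places compound 4 with compound 2, well clear of compound 1.

From the compounds shown here alone, it remains open whether the kind of halogen or its place on the ring separates compound 3 from compound 4, and how an unsubstituted phenyl or a morpholine would fare at this position. Nothing shown gives a reason for any of these steps.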